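A few compounds are considered here, and "the series" means these few. Any claim that something is new, unique, unknown or untested is made for them only; others in the source may bear on it.

The study looks at three measured compounds and one that is not yet measured. Compound 1 `CCC(C)OC(=O)C1=C(C)NC(=O)NC1c1ccco1` is the starting point: in an assay on membranes from HeLa cells for displacement of a labelled ligand from adenosine receptor A3 (Homo sapiens), read by scintillation counting, with a stated time of 180 min, tested at 1 uM (a lower number here means less inhibition, a higher number more inhibition at the concentration tested (going by the name of the read-out)), compound 1 gives 3%. Compound 2 `CC1=C(C(=O)OC2CCC2)C(c2ccco2)NC(=O)N1` differs from compound 1 by cyclobutyl in place of sec-butyl on an oxygen next to a carbonyl group, and in this assay compound 2 gives 1%. The step of a number 2 percentage points lower from compound 1 to compound 2 (within the scatter) is one the assay cannot tell apart from repetition. Compound 3 `CCC(C)OC(=O)C1=C(C)NC(=O)NC1c1ccoc1` differs from compound 1 by furan-3-yl in place of furan-2-yl on a saturated ring carbon, the two sharing the same atoms joined differently. In this assay compound 3 gives 11%, and the step of a number 8 percentage points higher from compound 1 to compound 3 (within the scatter) likewise lies within the scatter. The values of compound 2 and compound 3 are also within the scatter of each other, so none of the three stands apart.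

Compound 4 `CC1=C(C(=O)OC2CCC2)C(c2ccoc2)NC(=O)N1` has not been measured. It differs from compound 3 by cyclobutyl in place of sec-butyl on an oxygen next to a carbonyl group. This is the same change that separates compound 1 from compound 2, made on the other core; the two cores differ as described by furan-3-yl in place of furan-2-yl on a saturated ring carbon, and the place of the change is described in the same words in both cases. Because a number 2 percentage points lower from compound 1 to compound 2 (within the scatter) was a flat step, the step of a number 2 percentage points lower from compound 3 to compound 4 (within the scatter) is expected to be of the same flat kind. In this assay compound 4 is therefore estimated at 9%, with a likely range from 0% to 20%.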

Compound 4, a percentage reported as inhibition, at one concentration (the size of the read-out at that concentration, not a potency): 1%
Estimate against measurement, compound 4: 8 percentage points above; the measured number falls inside the stated range.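

In this assay, cyclobutyl in place of sec-butyl on an oxygen next to a carbonyl group gives a number 10 percentage points lower from compound 3 to compound 4 (within the scatter), and this step agrees with the one seen earlier on the other core: the same change on two cores in this assay, a number 2 percentage points lower (within the scatter) from compound 1 to compound 2 and a number 10 percentage points lower (within the scatter) from compound 3 to compound 4, 8 percentage points apart, within the scatter of two such steps. Furan-3-yl in place of furan-2-yl on a saturated ring carbon, read with cyclobutyl on the oxygen, gives no change at the digits printed from compound 2 to compound 4 (within the scatter), and this step likewise agrees with its earlier counterpart: the same change on two cores in this assay, a number 8 percentage points higher (within the scatter) from compound 1 to compound 3 and no change at the digits printed (within the scatter) from compound 2 to compound 4, 8 percentage points apart, within the scatter of two such steps. Both changes therefore carry from one core to the other with no difference the assay can detect, but every step among these four compounds lies within the scatter, so this shows only that neither change stands out from repetition on either core and does not show that either change has a real and transferable effect.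

The compounds shown leave open what a longer chain on that oxygen, or a phenyl ring or an amine in place of the furan, would do in this assay. They also leave open whether any change to this series can move the number beyond the scatter, and so whether a change with a clear effect would carry between cores in the same way.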